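Methoxy in place of chloro: compound 1 to compound 4

The compounds below may be only part of what the source reports. "The series", "measured", "known", "first", "only" and "open" are said of these compounds alone.

compound 1 `O=S(=O)(c1ccc(Cl)cc1)c1n[nH]c2cc(N3CCNCC3)ccc12`: 110 nM
compound 2 `CN1CCN(c2ccc3c(c2)c(S(=O)(=O)c2cccc4ccccc24)nn3Cc2ccccc2)CC1`: 2 nM
compound 3 `O=S(=O)(c1cccc(F)c1)c1n[nH]c2cccc(N3CCNCC3)c12`: 134 nM

In an assay on HeLa cells for displacement of a labelled ligand from 5-hydroxytryptamine receptor 6 (Homo sapiens) (a higher number here means a weaker inhibitor, a lower number a stronger inhibitor), compound 1 gives 110 nM, the second highest of the three numbers. Compound 3 gives 134 nM, a number within the scatter of compound 1. Compound 2 gives 2 nM, far lower and beyond the scatter, but compound 2 differs from compound 1 in several places at once, so nothing about any single change can be drawn from that pair.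

Compound 4 `COc1ccc(S(=O)(=O)c2n[nH]c3cc(N4CCNCC4)ccc23)cc1` differs from compound 1 by methoxy in place of chloro on an aromatic carbon. Within the data shown here, no measured pair in this set shows this change, so its size is unknown here. The expectation for compound 4 is a step of a 1.1-fold higher number from compound 1 to compound 4 (0.04 log units; within the scatter) in this assay, with no shift beyond the scatter in either direction. Compound 4 is therefore estimated at 120 nM, within 40 nM to 350 nM.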

Compound 4, inhibition constant: 124 nM
Compound 4: middle estimate off by 1.0-fold (0.01 log units), on the low side; the measured number falls inside the stated range.
By their numbers in this assay, from the lowest: compound 2; then compounds 1, 4 and 3 (each within the scatter of the next).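

In this assay, among these compounds, methoxy in place of chloro on an aromatic carbon, para to a large group, is the first single-place change that can be read, giving a 1.1-fold higher number from compound 1 to compound 4 (0.05 log units; within the scatter). This position therefore carries either group, with one heavy atom or two, without a shift beyond the scatter. No measurement here accounts for this result. Going by these compounds, whether an amine, a carboxylic acid or a longer chain such as butoxy would read the same at this position remains open. Also open, on these data alone, is whether methoxy for chloro behaves alike elsewhere on this ring.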